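The source may hold more compounds than are shown below. What is called first, only, known or untested is meant among the compounds shown, and "the series" means these compounds.

Compound 1 `CC/C(=C(/c1ccc(/C=C/C(=O)O)nc1)c1ccc2[nH]ncc2c1)c1ccccc1` gives 210 nM in a functional assay on MCF7 cells (Homo sapiens) for cytotoxicity, read by CellTiter-Glo, with a stated time of 5 days; on this read-out lower numbers stand for stronger inhibition and higher numbers for weaker inhibition; compound 2 `CC/C(=C(/c1ccc(/C=C/C(=O)O)cc1)c1ccc2[nH]ncc2c1)c1ccc(Cl)cc1` gives 15 nM.

Among these two numbers compound 2 stands lowest, and the higher number of compound 1 lies beyond the usual scatter. Compound 3 `CC/C(=C(/c1ccc(/C=C/C(=O)O)cc1)c1ccc2[nH]ncc2c1)c1cccnc1C` is not yet measured. It differs from compound 2 in one place: 2-methylpyridin-3-yl in place of 4-chlorophenyl on a double-bonded chain carbon bound to a double-bonded chain carbon and a saturated chain carbon. Going by the values given here, with no measured pair showing this change, the expectation rests on compound 2 alone, and the estimate is a modest step toward a higher number from compound 2 to compound 3 of a 4.0-fold higher number from compound 2 to compound 3 (0.60 log units; beyond the scatter). Compound 3 is expected at 60 nM, within 15 nM to 250 nM.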

Compound 3, half-maximal inhibitory concentration: 200 nM
Compound 3: middle estimate off by 3.3-fold (0.52 log units), on the low side; the range from low to high includes it.
By their numbers in this assay, from the lowest: compound 2; then compounds 3 and 1 (each within the scatter of the next).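

In this assay, 2-methylpyridin-3-yl in place of 4-chlorophenyl on the double-bonded chain carbon gives a 13-fold higher number from compound 2 to compound 3 (1.12 log units; beyond the scatter), the first step measured at this position. The number here therefore depends strongly on which ring is present, even though both groups have the same heavy-atom count. Nothing measured explains this step.

On these data alone, the ring nitrogen and the methyl enter together, so their separate contributions remain open. Compounds carrying 2-methylphenyl or pyridin-3-yl at this position would tell them apart.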